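Swapping pyridin-2-yl for pyridin-4-yl

The compounds below may be only part of what the source reports. "The series", "measured", "known", "first", "only" and "open" are said of these compounds alone.

In a functional assay on SMMC-7721 cells (Homo sapiens) for inhibition, read by MTT assay, with a stated time of 48 h (a higher number here means a weaker inhibitor, a lower number a stronger inhibitor), compound 1 `COc1cc(NC(=O)Nc2ccccn2)cc(-c2cccnc2)c1OC` gives 22400 nM. Two relatives have also been measured: compound 2 `COc1ccc(-c2cc(NC(=O)Nc3ccccn3)cc(OC)c2OC)cn1` gives 32900 nM, and compound 3 `O=C(Nc1ccccn1)Nc1cc(-c2cncnc2)ccc1OC(F)(F)F` gives 21600 nM. Neither relative lies beyond the usual scatter of repeat measurements from compound 1, so compound 1 sits within a close group of three numbers.

Compound 4 `COc1cc(NC(=O)Nc2ccncc2)cc(-c2cccnc2)c1OC` has not been measured yet. It keeps the core of compound 1 and alters one group: pyridin-4-yl in place of pyridin-2-yl on an amide-type nitrogen. The two compounds therefore contain the same atoms, joined differently, with pyridin-4-yl in place of pyridin-2-yl on an amide-type nitrogen.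

Among the measured compounds shown here, the only measured step in this small set, methoxy in place of hydrogen on an aromatic carbon, is a 1.5-fold higher number from compound 1 to compound 2 (0.17 log units; within the scatter). That is a different change and it stays within the scatter, so it offers only a weak guide. For the measured compounds named here, no measured pair tests the pyridinyl swap itself, which leaves no basis for picking a direction. The estimated step, a 1.0-fold lower number from compound 1 to compound 4 (0.01 log units; within the scatter), is expected to stay within the scatter of this assay. The expected range is kept wide to allow for the untested change. Compound 4 is estimated at 22000 nM, with an expected range from 10000 nM to 45000 nM.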

Compound 4, half-maximal inhibitory concentration: 73600 nM
Beside the measured number, compound 4's estimate is 3.3-fold (0.52 log units) below it; measured number outside the range, above it.
By their numbers in this assay, from the lowest: compounds 3, 1 and 2 (each within the scatter of the next); then compound 4.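

In this assay, among the compounds shown here, pyridin-4-yl in place of pyridin-2-yl on the amide-type nitrogen gives a 3.3-fold higher number from compound 1 to compound 4 (0.52 log units; beyond the scatter), and this is the first step in the set to go beyond the scatter, unlike a 1.5-fold higher number from compound 1 to compound 2 (0.17 log units; within the scatter). The two groups have the same atoms and the same counts of donors and acceptors, so what separates compound 1 from compound 4 is only how those atoms are joined, and this position therefore responds to a change that leaves the composition untouched. Nothing measured here shows why the number rises with this swap.

Still open, as far as these compounds go, is where a plain phenyl ring or a pyridin-3-yl group on the same amide-type nitrogen would fall, and whether either would stay close to compound 1 or move toward compound 4. From the compounds shown here alone, a single pair also sets no pattern, so it remains unknown whether the same swap would raise the number by a similar amount on the core of compound 3, which carries pyridin-2-yl at this place too.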